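A few compounds are considered here, and "the series" means these few. Any claim that something is new, unique, unknown or untested is made for them only; others in the source may bear on it.

Measured so far in an assay on HEK293 cells for positive allosteric modulation of metabotropic glutamate receptor 5 (Homo sapiens), read by FLIPR, with a stated time of 1 h; on this read-out lower numbers stand for an effect already at smaller amounts and higher numbers for an effect only at larger amounts of compound:
- compound 1 `O=C1NCCc2nc(C#Cc3ccccc3F)sc21`: 1500 nM
- compound 2 `CN1CCc2nc(C#Cc3ccccc3)sc2C1`: 34 nM
- compound 3 `O=C(C1CC1)N1CCc2nc(C#Cc3ccccc3)sc2C1`: a limit of the assay, > 10000 nM

Compound 2 holds the lowest of the two numbers in this assay; compound 1 gives 1500 nM, a higher number. The unmeasured compound 4 `O=C(C1CCCC1)N1CCc2nc(C#Cc3ccccc3)sc2C1` differs from compound 2 at one place: cyclopentylcarbonyl in place of methyl on an amine nitrogen in a ring. Among the compounds with values here, one measured step bears on this: an at least 290-fold higher number from compound 2 to compound 3 (2.46 log units; beyond the scatter), a loss that ran into the limit (the limit of > 10000 nM in this assay, at which 1 of the 3 values shown sits). A cyclopentylcarbonyl on the same amine nitrogen is expected to behave like the cyclopropylcarbonyl, so a large rise in number is expected for compound 4, with a 590-fold higher number from compound 2 to compound 4 (2.77 log units; beyond the scatter) likely ending at the limit again. Compound 4 is estimated at 20000 nM, in the range 5000 nM to 100000 nM.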

Compound 4, half-maximal effective concentration: 19 nM
For compound 4 the middle estimate is 1100-fold (3.02 log units) above the measured one; measured number below the stated range.
By their numbers in this assay, from the lowest: compounds 4 and 2 (each within the scatter of the next); then compound 1. At a limit, above all of these: compound 3.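

In this assay, the amine nitrogen in the ring can carry a carbonyl group with no change beyond the scatter: cyclopentylcarbonyl in place of methyl gives a 1.8-fold lower number from compound 2 to compound 4 (0.25 log units; within the scatter). The outcome instead turns on the group on the carbonyl carbon, where cyclopentyl in place of cyclopropyl gives an at least 520-fold lower number from compound 3 to compound 4 (2.72 log units; beyond the scatter). Compound 3 stands at a limit of the assay and not at a number: the limit of > 10000 nM in this assay, at which 1 of the 4 values shown sits.

The compounds shown leave open whether ring size alone sets this difference. Cyclobutyl, cyclohexyl or an open chain such as isopropyl on the carbonyl carbon would show where the change sets in.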